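Removing a Methyl Group: From Compound 1 to Compound 3

The source may report more compounds than this note shows. Statements on the series, on what has been measured and on what is new or still open speak of the compounds shown alone.

Compound 1, `C=C[C@H](/C=C\c1ccc(OC)cc1)c1ccc(O)cc1`: 45900 nM
Compound 2, `O=C(C#Cc1ccc(O)cc1)c1ccc(O)cc1`: 5300 nM

Of the compounds shown here, two have been measured so far. In a functional assay on 3T3-L1 cells (Mus musculus) for inhibition, with a stated time of 7 days (a higher number here means a weaker inhibitor, a lower number a stronger inhibitor), compound 1 gives 45900 nM, the highest of the two numbers, so it is the weaker inhibitor of the pair. In this assay compound 2 gives 5300 nM, a lower number, and the gap between the two lies beyond the usual scatter of repeated measurements. Compound 2 differs from compound 1 in more than one place, so its lower number cannot be tied to any single change.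

Compound 3, `C=C[C@H](/C=C\c1ccc(O)cc1)c1ccc(O)cc1`, is the next compound to be measured. It differs from compound 1 in a single spot: hydrogen in place of methyl on an oxygen on an aromatic ring. For the measured compounds named here, no measured pair isolates exactly this change, so the size of the step can only be guessed. Compound 2, the stronger inhibitor, carries a hydroxy group rather than a methoxy group on its second aromatic ring, which offers a hint that a lower number might follow. The step is therefore expected to be modest and toward a lower number, a 3.1-fold lower number from compound 1 to compound 3 (0.49 log units; beyond the scatter). Compound 3 is estimated to give 15000 nM in this assay, with a range from 5000 nM to 45000 nM.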

Compound 3, half-maximal inhibitory concentration: > 100000 nM
Compound 3 ended at the assay's limit (the forecaster's own chance of this, stated with the estimate: 5%); middle value at least 6.6-fold (0.82 log units) away from the limit.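

In this assay compound 3 gives > 100000 nM, which is a limit of the assay and not a number. The step can still be read in one direction: replacing methyl with hydrogen on an oxygen on an aromatic ring gives an at least 2.1-fold higher number from compound 1 to compound 3 (0.33 log units; beyond the scatter), so this single change weakens inhibition by more than the usual scatter, and the earlier pair of compounds, which differ in more than one place, could not show this. The methoxy group of compound 1 therefore does better here than the hydroxy group of compound 3, but the full size of the step stays unknown, as the reading for compound 3 stops at the top of the measurable range: the limit of > 100000 nM in this assay, at which 1 of the 3 values shown sits.

On these data alone, what remains open is whether the methyl group itself matters or whether any group on this oxygen would serve, which an ethyl group or a longer chain in its place would help to show. As far as these compounds go, it is also open whether an amine at this spot would behave like the hydroxy group of compound 3 or the methoxy group of compound 1.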